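The source may hold more compounds than are shown below. What is called first, only, known or untested is meant among the compounds shown, and "the series" means these compounds.

Compound 1 `COCc1ccc(Nc2nnc(Cc3c(Cl)cccc3Cl)o2)cc1` is the least toxic of the three compounds measured in an ADME assay on MT2 cells (Homo sapiens) for cytotoxicity, read by MTT assay (on this read-out higher numbers stand for lower toxicity in this test and lower numbers for higher toxicity in this test), where compound 1 gives 100000 nM. The other two share its arrangement of a diaryl-substituted central ring but differ in the halogen and in the group on the aniline ring. Compound 2 `Fc1cccc(F)c1Cc1cnc(Nc2ccc(CCOc3ccncc3)cc2)o1` gives 11000 nM in this assay, and compound 3 `N#Cc1ccc(Nc2ncc(Cc3c(F)cccc3F)o2)cc1` gives 7400 nM. Both gaps from compound 1 lie beyond the usual scatter, so compound 1 stands clearly highest. Among the measured compounds shown here, the only single-point step among the measured compounds, a 1.5-fold lower number from compound 2 to compound 3 (0.17 log units; within the scatter), concerns the aniline substituent and stays within the scatter.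

Compound 4 `Clc1cccc(Cl)c1Cc1nnc(Nc2ccc(COCc3ccco3)cc2)o1` differs from compound 1 by furan-2-yl in place of hydrogen on a saturated chain carbon bound to an oxygen on a saturated carbon. For the measured compounds named here, no measured step touches this saturated chain carbon, so the only guidance is the indifference of this assay to the change from compound 2 to compound 3 and the high number of compound 1. On that basis compound 4 is expected to land near compound 1, the step of a 1.7-fold lower number from compound 1 to compound 4 (0.22 log units; within the scatter) being an estimate with no firm direction, and the estimated value for compound 4 is 60000 nM with a range from 25000 nM to 100000 nM.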

Compound 4, half-maximal cytotoxic concentration: 12000 nM
The estimate for compound 4 lay 5.0-fold (0.70 log units) above the measured number; the measured number lies below the stated range.
By their numbers in this assay, from the lowest: compounds 3, 2 and 4 (each within the scatter of the next); then compound 1.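

In this assay, the saturated chain carbon bound to an oxygen on a saturated carbon proves responsive: furan-2-yl in place of hydrogen there gives an 8.3-fold lower number from compound 1 to compound 4 (0.92 log units; beyond the scatter), a change towards higher toxicity in this test. Among the compounds shown here, the only earlier step, a 1.5-fold lower number from compound 2 to compound 3 (0.17 log units; within the scatter), exchanged one group for another on an aromatic carbon and stayed within the scatter, so it gave no sign that a change on this part of the molecule could move the number beyond the scatter. Compound 4 keeps the core of compound 1 yet loses most of its high number, so that number does not come from the shared core alone, and the methoxymethyl group, read as ((furan-2-yl)methoxy)methyl in compound 4, matters here. No evidence is available that explains this step.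

On these data alone, whether the step belongs to the furan ring itself or would follow any group on this carbon stays open, and a phenyl ring, an ethyl chain or an amine in the same place would tell these apart. Also open, as far as these compounds go, is whether furan-2-yl would act the same way on the core of compound 3, which carries the two fluorines.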